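The compounds below may be only part of what the source reports. "The series", "measured", "known", "first", "only" and "open" are said of these compounds alone.

Working notes on the series

Compound 1 `COc1cc(/C=C/C(=O)/C=C/c2cccc3ccccc23)ccc1OCc1cn(CCCOc2cc(=O)oc3ccccc23)nn1` and compound 2 `COc1cc(/C=C/C(=O)/C=C/c2ccco2)ccc1OCc1cn(CCCOc2cc(=O)oc3ccccc23)nn1` stand on one core; compound 3 `COc1cc(/C=C/C(=O)/C=C/c2cccc3ccccc23)ccc1OCc1cn(CCCCOc2cc(=O)oc3ccccc23)nn1` and compound 4 `COc1cc(/C=C/C(=O)/C=C/c2ccco2)ccc1OCc1cn(CCCCOc2cc(=O)oc3ccccc23)nn1` stand on a second core, and the difference between the two cores is not broken down here. In a functional assay on COLO 205 cells (Homo sapiens) for inhibition, read by sulforhodamine B assay, with a stated time of 48 h, tested at 50 uM (on this read-out lower numbers stand for less inhibition of growth and higher numbers for more inhibition of growth at the one concentration tested), compound 1 gives 64%, while compound 2 gives 59% in this assay. The change between the two, (furan-2-yl in place of naphthalen-1-yl on a double-bonded chain carbon bound to a double-bonded chain carbon), produces a number 5 percentage points lower from compound 1 to compound 2 (within the scatter), so on this core the two aromatic groups are indistinguishable within the measurement.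

On the second core, compound 3 gives 50% in this assay. Set against compound 1 at 64%, the gap lies beyond the scatter; set against compound 2 at 59%, the gap lies within it.

Compound 4 has not been measured in this assay. It differs from compound 3 by furan-2-yl in place of naphthalen-1-yl on a double-bonded chain carbon bound to a double-bonded chain carbon, which is the same change at the same place as that from compound 1 to compound 2. Within the data shown here, the step from compound 3 to compound 4 in this assay is expected to be small, about a number 5 percentage points lower from compound 3 to compound 4 (within the scatter), an expectation that rests on the single earlier instance, a number 5 percentage points lower from compound 1 to compound 2 (within the scatter). Among the measured compounds shown here, only one prior example of the change exists, so the expectation is held loosely. Compound 4 is accordingly estimated at 45% in this assay, with the likely range running from 33% to 57%.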

Compound 4, percent growth inhibition at one concentration: 43%
For compound 4 the middle estimate is 2 percentage points above the measured one, and the stated range covers the measured number.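

In this assay, furan-2-yl in place of naphthalen-1-yl on the core of compound 3 gives a number 7 percentage points lower from compound 3 to compound 4 (within the scatter), so the change now has a reading on each of two cores: the same change on two cores in this assay, a number 5 percentage points lower (within the scatter) from compound 1 to compound 2 and a number 7 percentage points lower (within the scatter) from compound 3 to compound 4, 2 percentage points apart, within the scatter of two such steps

The change therefore carries from the core of compound 1 to the core of compound 3 with no difference that the measurement can detect, and on neither core can the two aromatic groups be told apart. This does not show that a real effect of fixed size transfers, since both steps lie within the scatter and the agreement may be no more than two small steps that cannot be resolved from noise; nor does a single change on two cores, read at one concentration in one cell line, show how a change with a larger step would carry over.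

The compounds shown leave open how far this place tolerates other groups, since it holds only naphthalen-1-yl and furan-2-yl. A phenyl ring, or an aromatic ring carrying an amine or a carboxylic acid, on the same double-bonded chain carbon would test whether the step stays this small and whether it still matches across both cores.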